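A few compounds are considered here, and "the series" means these few. Any claim that something is new, unique, unknown or untested is made for them only; others in the source may bear on it.

The measured compounds:

compound 1 `CC1CCCc2ncc(C(=O)O)c(=O)n21` gives 240 umol/kg
compound 2 `CC1CCn2c(ncc(C(=O)O)c2=O)/C1=N/Nc1ccccc1` gives 32 umol/kg
compound 3 `CC1CC/C(=N\Nc2ccccc2F)c2ncc(C(=O)O)c(=O)n21` gives 5 umol/kg

All three were run in a functional assay on the whole organism for inhibition, with Rattus norvegicus as the target; a lower number here means that less compound is needed, a higher number that more compound is needed for the effect. Compound 1 gives 240 umol/kg, compound 2 gives 32 umol/kg, and compound 3 gives 5 umol/kg. Compound 3 stands lowest of the three numbers; the nearest is compound 2, whose number is higher by an amount beyond the scatter, and the furthest is compound 1, higher still and also beyond the scatter. Within this small set, compound 3 therefore needs the least compound for the effect.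

The next compound, compound 4 `CC1CC/C(=N\Nc2ccc(Cl)cc2)c2ncc(C(=O)O)c(=O)n21`, differs from compound 3 in one place: 4-chlorophenyl in place of 2-fluorophenyl on an amine nitrogen. For the measured compounds named here, no step of this kind between two measured compounds is available, so there is nothing in the set that shows how this exchange moves the number in this assay. The exchange keeps the size of the group and its ring, and changes only which halogen is present and where it sits on the ring, as named above. Going by the values given here, with no precedent, the expectation is a step from compound 3 to compound 4 of about a 1.6-fold higher number from compound 3 to compound 4 (0.20 log units; within the scatter), that is, no change beyond the scatter, with the direction left open. Compound 4 is thus estimated to give 8 umol/kg, in a range from 2 umol/kg to 30 umol/kg.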

Compound 4, dose for 50% inhibition: 0.5 umol/kg
Estimate against measurement, compound 4: 16-fold (1.20 log units) above; measured number below the stated range.
By their numbers in this assay, from the lowest: compound 4; then compound 3; then compound 2; then compound 1.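

For the compounds shown here, this is the first step in the set that differs in one place, and it shows that the group on the amine nitrogen matters in this assay: 4-chlorophenyl in place of 2-fluorophenyl gives a 10-fold lower number from compound 3 to compound 4 (1.00 log units; beyond the scatter), which is beyond the scatter. The two groups have the same count of heavy atoms, the same single six-membered aromatic ring of carbon, and no hydrogen-bond donors or acceptors, so a step of this size arises here without any change in those counts. The compounds shown offer no measurement that would explain why the number falls with this exchange.

Both the halogen and its place on the ring change in this one step, so the compounds shown do not tell how much of it belongs to chlorine in place of fluorine and how much to the new place; 4-fluorophenyl and 2-chlorophenyl on the same nitrogen would separate the two. As far as these compounds go, it also remains open whether the step depends on a halogen at all, or whether a group such as 4-methoxyphenyl or 4-methylphenyl would give a similar number.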